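This account rests on a few compounds, and the source may have more. Where it says the series, first, only, none or still open, it means among the compounds named here.

Measured in a functional assay on HCT-116 cells (Homo sapiens) for inhibition, read by sulforhodamine B assay, with a stated time of 48 h, tested at 50 uM; on this read-out lower numbers stand for less inhibition of growth and higher numbers for more inhibition of growth at the one concentration tested:

Compound 1 `O=C1C(=O)N(CCCCCn2cc(COc3cc(=O)oc4ccccc34)nn2)c2ccc(Cl)cc21` gives 52% in this assay.
Compound 2 `O=C1C(=O)N(CCCCCn2cc(COc3cc(=O)oc4ccccc34)nn2)c2ccc(Br)cc21` gives 43% in this assay.
Compound 3 `O=C1C(=O)N(CCCn2cc(COc3cc(=O)oc4ccccc34)nn2)c2ccc(Br)cc21` gives 66% in this assay.

Compound 1 and compound 2 differ in one place only: chloro in place of bromo on an aromatic carbon. This step gives a number 9 percentage points higher from compound 2 to compound 1 (within the scatter). Compound 3 and compound 2 share the halogen but have different cores; the difference between the two cores is not broken down here. Compound 3 shows the highest number of the three, and its distance to compound 1 and to compound 2 lies beyond the scatter.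

Compound 4 `O=C1C(=O)N(CCCn2cc(COc3cc(=O)oc4ccccc34)nn2)c2ccc(Cl)cc21` differs from compound 3 by chloro in place of bromo on an aromatic carbon, the same change seen from compound 2 to compound 1. The expected step of a number 6 percentage points higher from compound 3 to compound 4 (within the scatter) is estimated to match the earlier one, because a number 9 percentage points higher from compound 2 to compound 1 (within the scatter) was small. Compound 4 is therefore expected to give about 72%, somewhere between 58% and 86%.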

Compound 4, percent growth inhibition at one concentration: 68%
Estimate against measurement, compound 4: 4 percentage points above; measured number inside the range.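

In this assay, chloro in place of bromo on an aromatic carbon gives a number 2 percentage points higher from compound 3 to compound 4 (within the scatter). As far as these two pairs can tell, the change carries over from one core to the other: the same change on two cores in this assay, a number 9 percentage points higher (within the scatter) from compound 2 to compound 1 and a number 2 percentage points higher (within the scatter) from compound 3 to compound 4, 7 percentage points apart, within the scatter of two such steps On neither core does this swap of one halogen for the other move the number beyond the usual scatter, but two pairs in a single assay do not show that the step would stay this small on other cores, and they do not explain it.

The compounds shown leave open how other groups on that aromatic carbon, such as fluoro, methoxy or nitrile, would compare with chloro and bromo. They also leave open how plain hydrogen there would compare.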